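Removing both hydroxyls from the hydrazone aryl ring

This account rests on a few compounds, and the source may have more. Where it says the series, first, only, none or still open, it means among the compounds named here.

Compound 1 `O=C(N/N=C/c1cccc(O)c1O)c1ccc(-c2nc3ccccc3s2)cc1` carries a 2,3-dihydroxyphenyl on the hydrazone carbon. In an assay on isolated protein for inhibition of Maltase-glucoamylase (Homo sapiens), with a stated time of 15 min (on this read-out lower numbers stand for stronger inhibition and higher numbers for weaker inhibition), compound 1 gives 11200 nM, the higher of the two numbers measured, though its nearest neighbour compound 2 `O=C(N/N=C/c1ccc(O)cc1O)c1ccc(-c2nc3ccccc3s2)cc1`, which gives 5580 nM, sits within the scatter of it: the step of a 2.0-fold lower number from compound 1 to compound 2 (0.30 log units; within the scatter) is too small to rank the two. Compound 3 `COc1ccc(/C=N/NC(=O)c2ccc(-c3nc4ccccc4s3)cc2)cc1O`, which keeps one hydroxyl and adds a methoxy, is reported in this assay as "not active" (no number reported), with no number given.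

Compound 4 `COc1ccc(/C=N/NC(=O)c2ccc(-c3nc4ccccc4s3)cc2)cc1` differs from compound 1 in one place: 4-methoxyphenyl in place of 2,3-dihydroxyphenyl on a carbon with a double bond to nitrogen. Among the compounds with values here, no measured step bears on this change directly. Within the data shown here, the step from compound 1 to compound 2 shows only that moving a hydroxyl changes little. Compound 3 bears more closely, since it already has lost one hydroxyl in favour of a methoxy and was inactive, and compound 4 goes further in the same direction by losing the second hydroxyl as well.

Compound 4 is therefore expected to lose potency, with a 5.4-fold higher number from compound 1 to compound 4 (0.73 log units; beyond the scatter), and may well be reported as inactive. The estimate for compound 4 in this assay is 60000 nM, within a range of 20000 nM to 200000 nM.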

Compound 4, half-maximal inhibitory concentration: 18300 nM
For compound 4 the middle estimate is 3.3-fold (0.52 log units) above the measured one; the measured number lies below the stated range.
By their numbers in this assay, from the lowest: compounds 2, 1 and 4 (each within the scatter of the next, the first and the last beyond it).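

In this assay, hydroxyls on the aryl group are not needed for a measurable number at this position: 4-methoxyphenyl, with 0 hydrogen-bond donors, stands in place of 2,3-dihydroxyphenyl with a step of a 1.6-fold higher number from compound 1 to compound 4 (0.21 log units; within the scatter), so this replacement cannot be told apart from the parent. Set against 2,4-dihydroxyphenyl, the same group does separate, with a modest step of a 3.3-fold higher number from compound 2 to compound 4 (0.52 log units; beyond the scatter), which makes this the first step at this position to lie beyond the scatter. Compound 4 also gives a number where compound 3, which keeps a hydroxyl alongside its methoxy, is reported as "not active" (no number reported), and nothing on hand accounts for that contrast.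

The compounds shown leave open how much of the reading of compound 4 belongs to its methoxy group and how much to the absence of hydroxyls, a question that a plain unsubstituted phenyl on the same carbon would address. They also leave open how this position would respond to an amine or a carboxylic acid on the aryl ring.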